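The source may hold more compounds than are shown below. What is called first, only, known or untested is meant among the compounds shown, and "the series" means these compounds.

In a functional assay on the whole organism for positive allosteric modulation, with Mus musculus as the target (a lower number here means that less compound is needed, a higher number that more compound is needed for the effect), compound 1 `CCC(=O)N(c1cccc(Br)c1)C1CCCC1N(C)C` gives 2 mg/kg. Compound 2 `CCC(=O)N(c1ccc(Br)cc1)C1CCCC1N(C)C` reads > 50 mg/kg, which is a limit of the assay and not a number. Compound 3 `CCC(=O)N(c1ccc(Br)c(Br)c1)C1CCCC1N(C)C` differs from compound 2 by bromo in place of hydrogen on an aromatic carbon, ortho to a bromo group and meta to a large group. For the measured compounds named here, no measured step covers this change. A moderate fall in the dose needed in this assay is expected, since compound 1, with its bromo meta to a large group, gives 2 mg/kg. The expected change is an at least 3.3-fold lower number from compound 2 to compound 3 (0.52 log units; beyond the scatter). For compound 3 the estimate is 15 mg/kg, with an expected range of 3 mg/kg to 70 mg/kg.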

Compound 3, dose for half-maximal effect: 0.5 mg/kg
Beside the measured number, compound 3's estimate is 30-fold (1.48 log units) above it; the measured number lies below the stated range.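

In this assay compound 2 stands at a limit of the assay and not at a number: the limit of > 50 mg/kg in this assay, at which 1 of the 3 values shown sits.
The bromo placed ortho to a bromo group and meta to a large group gives an at least 100-fold lower number from compound 2 to compound 3 (2.00 log units; beyond the scatter), so this position carries the effect in the compounds shown.
Seen from the other side, there is a 4.0-fold lower number from compound 1 to compound 3 (0.60 log units; beyond the scatter), so the bromo that compound 2 carries alone does not cancel the effect once the second bromo is present.

On these data alone, whether chloro or trifluoromethyl can replace either bromo remains open.
So does whether a methoxy group at this position gives a similar step.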